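A few compounds are considered here, and "the series" means these few. Any claim that something is new, unique, unknown or untested is made for them only; others in the source may bear on it.

Working notes on the series. Compound 1 `COC(=O)C[C@H](NC(=O)OC(C)(C)C)C(=O)N(C1CC1)C1(C(=O)NCc2ccccc2)CCN(Cc2ccccc2)CC1` gives 84000 nM in an ADME assay on MDCK cells (Canis lupus familiaris) for cytotoxicity, read by microscopy, with a stated time of 72 h; on this read-out higher numbers stand for lower toxicity in this test and lower numbers for higher toxicity in this test. Compound 2 `COC(=O)C[C@H](N)C(=O)N(Cc1ccc(F)cc1)C1(C(=O)NCc2ccccc2)CCN(Cc2ccccc2)CC1` gives 60000 nM in this assay. Compound 3 `COC(=O)C[C@H](NC(=O)OCc1ccccc1)C(=O)N(Cc1ccc(F)cc1)C1(C(=O)NCc2ccccc2)CCN(Cc2ccccc2)CC1` gives 2600 nM in this assay, the lowest of the three numbers, with compound 2 nearest and compound 1 furthest. Going by the values given here, the only measured step is a 23-fold lower number from compound 2 to compound 3 (1.36 log units; beyond the scatter), at the carbamate position.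

Compound 4 `COC(=O)C[C@H](NC(=O)OCc1ccccc1)C(=O)N(C1CC1)C1(C(=O)NCc2ccccc2)CCN(Cc2ccccc2)CC1` is the next compound for this assay. The change from compound 3 is cyclopropyl in place of 4-fluorobenzyl on an amide-type nitrogen. Among the compounds with values here, no measured step touches this amide nitrogen alone: compound 1 and compound 2 differ in two places, so only their numbers can be compared, and compound 1, which already carries cyclopropyl, shows 84000 nM while compound 2 shows 60000 nM. Both carbamate-bearing compounds run toward lower numbers, so compound 4 is read as near compound 3 with some allowance for a higher number. Compound 4 is expected at 8000 nM, within 2000 nM to 40000 nM. The step implied by this estimate is a 3.1-fold higher number from compound 3 to compound 4 (0.49 log units; beyond the scatter), a modest expected rise.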

Compound 4, minimum cytotoxic concentration: 20000 nM
Compound 4: middle estimate off by 2.5-fold (0.40 log units), on the low side; measured number inside the range.
By their numbers in this assay, from the lowest: compound 3; then compound 4; then compounds 2 and 1 (each within the scatter of the next).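

Going by these compounds alone, on the amide-type nitrogen, cyclopropyl in place of 4-fluorobenzyl gives a 7.7-fold higher number from compound 3 to compound 4 (0.89 log units; beyond the scatter) in this assay, the first reading of this position in which nothing else changes, and the step lies beyond the scatter. With cyclopropyl held fixed, benzyl in place of tert-butyl on an oxygen next to a carbonyl group gives a 4.2-fold lower number from compound 1 to compound 4 (0.62 log units; beyond the scatter), so the group on this oxygen also moves the number beyond the scatter. No measurement shown accounts for either step.

A cyclohexyl group or an unsubstituted benzyl on the amide-type nitrogen would help show whether the rise follows the three-membered ring or the departure of the aromatic ring and its fluorine. From the compounds shown here alone, the size of the tert-butyl to benzyl step with 4-fluorobenzyl on that nitrogen remains open.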